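The source may report more compounds than this note shows. Statements on the series, on what has been measured and on what is new or still open speak of the compounds shown alone.

Measured so far in a functional assay on the whole organism for inhibition, with Rattus norvegicus as the target, at a dose of 50 mg/kg by the oral route; a lower number here means a weaker effect, a higher number a stronger effect of the compound at the dose given:
compound 1 `Cn1c(-c2ccccc2)cc(=O)[nH]c1=O`: 47%
compound 2 `Cn1c(-c2ccccc2)c(Br)c(=O)[nH]c1=O`: 43%
compound 3 `Cn1c(-c2ccccc2)c(I)c(=O)[nH]c1=O`: 44%

All three numbers sit within the usual scatter of one another: a number 4 percentage points lower from compound 1 to compound 2 (within the scatter), a number 3 percentage points lower from compound 1 to compound 3 (within the scatter) and a number 1 percentage points higher from compound 2 to compound 3 (within the scatter) are each within the scatter, so compound 2 cannot be set apart from compound 1 or compound 3 on these numbers.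

The next compound, compound 4 `Cn1c(-c2ccccc2)c(Br)c(=O)n(C)c1=O`, differs from compound 2 in one place: methyl in place of hydrogen on an aromatic nitrogen.

Going by the values given here, none of the measured steps touches the aromatic nitrogen; each of them swaps one halogen for another, or for hydrogen, on an aromatic carbon. Among the compounds with values here, there is therefore no measured step that bears directly on the change from compound 2 to compound 4. What the series does show is that three changes on the core have all left this assay within the scatter. Taken as the only guide, that gives no reason to expect a step beyond the scatter, but the uncertainty is wide, since the change to compound 4 is of a different kind.

Compound 4 is accordingly expected to give about 40% in this assay, between 20% and 60%, meaning an expected step of a number 3 percentage points lower from compound 2 to compound 4 (within the scatter).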

Compound 4, a percentage reported as inhibition, in the whole organism at one dose (the size of the read-out at that dose, not a potency): 36%
For compound 4 the middle estimate is 4 percentage points above the measured one, within the range that was stated.
By their numbers in this assay, from the lowest: compounds 4, 2, 3 and 1 (each within the scatter of the next, the first and the last beyond it).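

Methyl in place of hydrogen on an aromatic nitrogen gives, in this assay, a number 7 percentage points lower from compound 2 to compound 4 (within the scatter), and this is the first measured change in the series away from the aromatic carbon. On these numbers compound 4 cannot be set apart from compound 2, so with bromo on the core, the hydrogen on this nitrogen can be replaced by methyl without a step beyond the scatter, and inhibition persists at the dose given. No measurement is available that bears on what lies behind this step.

The compounds shown leave open whether the same replacement would also stay within the scatter on the iodo compound 3 or on compound 1, which carries hydrogen on that aromatic carbon, since a single pair cannot show whether the result depends on the bromo group. They also leave open what a longer chain such as propyl, a benzyl group or a chain ending in a carboxylic acid would do on this nitrogen, and, as the read-out reflects the effect at one dose, how the effects of any of these compounds would compare at other doses.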